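Adding a Cyano Group to Compound 3

The source may report more compounds than this note shows. Statements on the series, on what has been measured and on what is new or still open speak of the compounds shown alone.

compound 1 `Cc1cnn(C(=O)N2CCCCC2)c1` 1100 nM
compound 2 `Cc1cnn(C(=O)N(C)CCN(C)Cc2ccc(OCc3ccccc3)cc2)c1` 1200 nM
compound 3 `CN(CCN(C)C(=O)n1cccn1)Cc1ccc(OCc2ccccc2)cc1` 530 nM

In an assay on membranes from brain for binding affinity to Monoacylglycerol lipase ABHD6 (Mus musculus), read by fluorescence, with stated times of 1 h and 30 min (on this read-out higher numbers stand for weaker inhibition and lower numbers for stronger inhibition), compound 1 gives 1100 nM, compound 2 gives 1200 nM and compound 3 gives 530 nM. Compound 3 stands lowest of the three numbers, and both the gap to compound 1 and the step of a 2.3-fold lower number from compound 2 to compound 3 (0.35 log units; beyond the scatter) lie beyond the scatter. Compound 4 `CN(CCN(C)C(=O)n1cc(C#N)cn1)Cc1ccc(OCc2ccccc2)cc1` differs from compound 3 by cyano in place of hydrogen on an aromatic carbon. Going by the values given here, the only measured step at this ring carbon is a 2.3-fold lower number from compound 2 to compound 3 (0.35 log units; beyond the scatter), and it concerned a methyl group rather than a cyano group, so no measured step bears directly on the change. No step beyond the scatter is therefore expected in this assay. Compound 4 is expected to give about 500 nM, within a range of 150 nM to 1600 nM. This estimate means a step of a 1.1-fold lower number from compound 3 to compound 4 (0.03 log units; within the scatter).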

Compound 4, half-maximal inhibitory concentration: 320 nM
The estimate for compound 4 lay 1.6-fold (0.19 log units) above the measured number, and the stated range covers the measured number.
By their numbers in this assay, from the lowest: compounds 4 and 3 (each within the scatter of the next); then compounds 1 and 2 (each within the scatter of the next).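

In this assay cyano in place of hydrogen on this aromatic carbon gives a 1.7-fold lower number from compound 3 to compound 4 (0.22 log units; within the scatter) and so no change that can be told from the scatter, which shows that this carbon can carry a nitrile as well as a hydrogen. Cyano in place of methyl gives a 3.8-fold lower number from compound 2 to compound 4 (0.57 log units; beyond the scatter) and so, among the three groups shown at this carbon, only the methyl compound stands apart. Going by these compounds, whether an amine, a carboxylic acid or a longer chain would be accommodated at this carbon remains open, as does whether the cyano step carries over to the core of compound 1. No evidence at hand explains these numbers.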